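This account rests on a few compounds, and the source may have more. Where it says the series, first, only, none or still open, it means among the compounds named here.

Compound 1 `Cc1cc(Cl)c2c(c1O)C(=O)C=CC2=O` gives 10000 nM
Compound 2 `CC(=O)Oc1c(C)cc(Cl)c2c1C(=O)C=CC2=O` gives 18700 nM

Both compounds were tested in a functional assay on MCF7 cells (Homo sapiens) for cytotoxicity, read by XTT assay, with a stated time of 24 h; on this read-out lower numbers stand for stronger inhibition and higher numbers for weaker inhibition. Within the data shown here, there, compound 2 at 18700 nM lies within the scatter of compound 1, the only other measured compound. Compound 3 `CCOc1c(C)cc(Cl)c2c1C(=O)C=CC2=O` is still to be measured. It differs from compound 2 as follows: ethyl in place of acetyl on an oxygen on an aromatic ring. That is, compound 3 carries ethyl where compound 2 carries acetyl. Among the measured compounds shown here, one measured step bears on this change, a 1.9-fold higher number from compound 1 to compound 2 (0.27 log units; within the scatter), where acetyl replaces hydrogen on that oxygen. This step stays within the scatter. For the measured compounds named here, no measured compound carries the ethyl group, so the evidence is thin. No step beyond the scatter is therefore expected in this assay. The expected change is a 1.3-fold lower number from compound 2 to compound 3 (0.13 log units; within the scatter). For compound 3 the estimated value is 14000 nM, with an expected range from 6000 nM to 35000 nM.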

Compound 3, half-maximal inhibitory concentration: 32200 nM
Beside the measured number, compound 3's estimate is 2.3-fold (0.36 log units) below it, within the range that was stated.
By their numbers in this assay, from the lowest: compounds 1, 2 and 3 (each within the scatter of the next, the first and the last beyond it).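

In this assay, ethyl in place of acetyl on this oxygen gives a 1.7-fold higher number from compound 2 to compound 3 (0.24 log units; within the scatter) and so remains a change that this read-out does not separate. Ethyl in place of hydrogen on the same oxygen gives a 3.2-fold higher number from compound 1 to compound 3 (0.51 log units; beyond the scatter) and is the first step here to pass the scatter, though only modestly, which the acetyl group had not done. No measurement shown accounts for this step.

Going by these compounds, whether a longer chain such as propyl or butyl on this oxygen would carry the trend further remains open, as does the outcome with a carboxylic acid or an amine at the end of such a chain. The chlorine and methyl groups are also the same in all the compounds shown, so nothing can be said about changes at those places.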